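This account rests on a few compounds, and the source may have more. Where it says the series, first, only, none or still open, it means among the compounds named here.

In an ADME assay on L02 cells (Homo sapiens) for cytotoxicity, read by MTT assay, with a stated time of 24 h (on this read-out lower numbers stand for stronger inhibition and higher numbers for weaker inhibition), three compounds have been measured: compound 1 `COc1cc(/C=C2\CN(S(=O)(=O)c3ccc(F)cc3)C/C(=C\c3ccccc3F)C2=O)cc(OC)c1` gives 18500 nM, compound 2 `CC(=O)Nc1ccc(S(=O)(=O)N2C/C(=C\c3ccc(C#N)cc3)C(=O)/C(=C/c3ccccc3F)C2)cc1` gives 14400 nM and compound 3 `COc1cc(/C=C2\CN(S(=O)(=O)c3ccc(NC(C)=O)cc3)C/C(=C\c3ccccc3F)C2=O)cc(OC)c1OC` gives 14000 nM. Compound 3 thus stands within the scatter of both others. Compound 4 `COc1cc(/C=C2\CN(S(=O)(=O)c3ccc(NC(C)=O)cc3)C/C(=C\c3ccccc3F)C2=O)cc(OC)c1` differs from compound 3 in one place: hydrogen in place of methoxy on an aromatic carbon, so that 3,4,5-trimethoxyphenyl becomes 3,5-dimethoxyphenyl. The measured step that bears on this, a 1.0-fold lower number from compound 2 to compound 3 (0.01 log units; within the scatter), concerns the same substituent and stayed within the scatter. No step beyond the scatter is therefore expected in this assay. The expected change is a 1.1-fold higher number from compound 3 to compound 4 (0.04 log units; within the scatter). The estimated value for compound 4 is 15500 nM, with an expected range from 9000 nM to 26000 nM.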

Compound 4, half-maximal inhibitory concentration: 15400 nM
Compound 4: middle estimate off by 1.0-fold (0.00 log units), on the high side, within the range that was stated.
By their numbers in this assay, from the lowest: compounds 3, 2, 4 and 1 (each within the scatter of the next).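

In this assay, among these compounds, hydrogen in place of the methoxy that sits para to a large group and ortho to two methoxy groups gives a 1.1-fold higher number from compound 3 to compound 4 (0.04 log units; within the scatter) and so tests this position directly for the first time. The 3,5-dimethoxyphenyl group in place of 4-cyanophenyl gives a 1.1-fold higher number from compound 2 to compound 4 (0.03 log units; within the scatter) and acetamido in place of fluoro gives a 1.2-fold lower number from compound 1 to compound 4 (0.08 log units; within the scatter) as a further step within the scatter. Compound 4 therefore adds three comparisons, none of them beyond the scatter.

As far as these compounds go, whether an amine or a carboxylic acid at this position would shift the number beyond the scatter remains open. Nothing available here explains these results.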